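Cytotoxicity of Two Diaryl Ether Sulfonamides and a Fluorinated Analogue

The source may hold more compounds than are shown below. What is called first, only, known or untested is meant among the compounds shown, and "the series" means these compounds.

Measured compounds:
Compound 1 `Cc1cc(S(N)(=O)=O)ccc1NC(=O)COc1ccc(Cl)cc1Oc1ccc2ccccc2c1`: 119000 nM
Compound 2 `Cc1cc(S(N)(=O)=O)ccc1NC(=O)COc1ccc(F)cc1Oc1ccc2ccccc2c1C`: 56100 nM

Among the measured compounds shown here, in an ADME assay on C8166 cells (Homo sapiens) for cytotoxicity, read by MTT assay (on this read-out higher numbers stand for lower toxicity in this test and lower numbers for higher toxicity in this test), compound 2 gives 56100 nM, the lowest of the two numbers so far; compound 1 gives 119000 nM, a gap beyond the scatter. Compound 3 `Cc1cc(S(N)(=O)=O)ccc1NC(=O)COc1ccc(F)cc1Oc1ccc2cccc(F)c2c1` differs from compound 2 in one place: 8-fluoronaphthalen-2-yl in place of 1-methylnaphthalen-2-yl on an oxygen on an aromatic ring. For the measured compounds named here, no measured pair shows this exact change, so its direction is unknown here. A small step of a 1.2-fold higher number from compound 2 to compound 3 (0.10 log units; within the scatter) is expected, not clearly beyond the scatter of this assay. Compound 3 is therefore estimated at 70000 nM, with a likely range from 30000 nM to 170000 nM.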

Compound 3, half-maximal cytotoxic concentration: 171000 nM
The estimate for compound 3 lay 2.4-fold (0.39 log units) below the measured number; measured number outside the range, above it.
By their numbers in this assay, from the lowest: compound 2; then compounds 1 and 3 (each within the scatter of the next).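

Replacing 1-methylnaphthalen-2-yl with 8-fluoronaphthalen-2-yl on an oxygen on an aromatic ring gives, in this assay, a 3.0-fold higher number from compound 2 to compound 3 (0.48 log units; beyond the scatter) and so points to lower toxicity in this test. This group can therefore shift the read-out by more than the usual scatter, which compounds 1 and 2 could not show, as they differ in more than one place. Nothing available explains the shift. On these data alone, the swap removes the methyl and adds the fluorine together, so the share of each remains open. As far as these compounds go, how an amine on this group would read out is also open.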